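The compounds below may be only part of what the source reports. "The series", "measured", "known", "first", "only" and "open" are said of these compounds alone.

The three measured compounds share a core and differ in the group on the sulfur and in the linker to the amide. In a functional assay on A-375 cells (Homo sapiens) for inhibition, read by CCK-8 assay, with a stated time of 72 h, tested at 2 uM (a lower number here means less inhibition of growth, a higher number more inhibition of growth at the concentration tested), compound 1 `COc1ccc(SCc2ccc(/C=C/C(=O)Nc3ccccc3N)cc2)cc1OC` gives 46%, compound 2 `Nc1ccccc1NC(=O)/C=C/c1ccc(CSc2ccc(Cl)cc2)cc1` gives 13.4%, and compound 3 `Cc1ccc(SCc2ccc(C(=O)Nc3ccccc3N)cc2)cc1` gives 17.5%. Compound 3 thus stands second highest of the three: its number and that of compound 2 lie within the scatter of each other, while compound 1 sits beyond the scatter above it. For the measured compounds named here, the only measured step is a number 32.6 percentage points lower from compound 1 to compound 2 (beyond the scatter), a large fall.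

Compound 4 `Nc1ccccc1NC(=O)c1ccc(CSc2ccc(Cl)cc2)cc1` is not yet measured. It differs from compound 3 by chloro in place of methyl on an aromatic carbon. Going by the values given here, no measured pair shows exactly this exchange; the step from compound 1 to compound 2 is the only one in which a chloro enters, and it was large, but it replaced a different group on a scaffold with a different linker, so it bears on compound 4 only loosely. Compound 2 already carries the (4-chlorophenyl)sulfanyl group and gives a number close to that of compound 3. The step is therefore expected to be small, a number 4.5 percentage points lower from compound 3 to compound 4 (within the scatter), within the scatter. Compound 4 is estimated at 13%, with a range from 3% to 25%.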

Compound 4, percent growth inhibition at one concentration: 25.3%
Compound 4: middle estimate off by 12.3 percentage points, on the low side, and the stated range ends below it.
By their numbers in this assay, from the lowest: compounds 2, 3 and 4 (each within the scatter of the next, the first and the last beyond it); then compound 1.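

In this assay, chloro in place of methyl on an aromatic carbon, para to a large group, gives a number 7.8 percentage points higher from compound 3 to compound 4 (within the scatter), so on the linker of compound 3 this single exchange on the ring attached to sulfur is not told apart from the usual variation. For the compounds shown here, this is the first direct reading of the exchange, and it differs from the large fall on the other linker, a number 32.6 percentage points lower from compound 1 to compound 2 (beyond the scatter), where 4-chlorophenyl replaced 3,4-dimethoxyphenyl; that step therefore remains the only sign that the group on sulfur can matter, and it holds for one pair only. No measurement offered here accounts for the result.

Going by these compounds alone, whether a different group at this position, such as an amine or a carboxylic acid, would move the number beyond the scatter remains open, since methyl and chloro are the only two groups compared here. From the compounds shown here alone, it is also open whether 3,4-dimethoxyphenyl on the linker of compound 3 would match compound 1 at 46%, or whether its high number depends on the linker that compound 1 carries.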